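The compounds below may be only part of what the source reports. "The series", "measured", "known", "first", "only" and "open" are said of these compounds alone.

Working notes on the series.

Of the compounds shown here, two have been measured in a functional assay on the whole organism (aorta, strain Wistar) with Rattus norvegicus as the target; a lower number here means a smaller maximal response, a higher number a larger maximal response. Compound 1 `CCCCc1nc(Cl)c(COC(=O)c2ccc(C(C)O[N+](=O)[O-])cc2)n1Cc1ccc(-c2ccccc2-c2nn[nH]n2)cc1` reaches a maximal response of 100% in this assay. Compound 2 `CCCCc1nc(Cl)c(C(=O)Oc2cccc(CO[N+](=O)[O-])c2)n1Cc1ccc(-c2ccccc2-c2nn[nH]n2)cc1` reaches 100% in this assay, which places compound 2 level with compound 1 at the digits shown, and the two values lie within the scatter of each other. Within the data shown here, no step between the measured compounds is to be drawn, since compound 1 and compound 2 differ in more than one place.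

Compound 3 `CCCCc1nc(Cl)c(C(=O)Oc2ccc(CO[N+](=O)[O-])cc2)n1Cc1ccc(-c2ccccc2-c2nn[nH]n2)cc1` has not yet been measured in this assay. It keeps the shared core of compound 2 and differs from it only in one place: 4-((nitrooxy)methyl)phenyl in place of 3-((nitrooxy)methyl)phenyl on an oxygen next to a carbonyl group. The two compounds hold the same atoms joined differently. Among the measured compounds shown here, with both measured compounds reaching the reference level in this assay, and with no step on record to guide the size of the change, the expectation for the step from compound 2 to compound 3 is none beyond the scatter, i.e. an estimated step of no change at the digits printed from compound 2 to compound 3 (within the scatter). Compound 3 is expected to reach about 100% in this assay, with a range from 88% to 110%.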

Compound 3, largest response reached (Emax), in percent of the reference or control that the assay uses: 100%
Beside the measured number, compound 3's estimate shows no gap at the digits printed, within the range that was stated.
By their numbers in this assay, from the lowest: compounds 1, 2 and 3 (each within the scatter of the next).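

In this assay, among these compounds, 4-((nitrooxy)methyl)phenyl in place of 3-((nitrooxy)methyl)phenyl on an oxygen next to a carbonyl group gives no change at the digits printed from compound 2 to compound 3 (within the scatter) and this is the first step that differs in one place only. At this position, on this read-out, the two arrangements of the same atoms cannot be told apart, so the maximal response does not depend measurably on which of these two named groups is present. Nothing on record explains this outcome.

The maximal response alone leaves open how much compound is needed to reach it, so compound 2 and compound 3 could still differ in ways this read-out does not capture. As far as these compounds go, it also remains open whether the response would hold with a different group on the same oxygen, such as a plain phenyl without the nitrooxy group, a hydroxymethyl in place of the (nitrooxy)methyl, or a longer chain carrying the nitrooxy group.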